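The source may hold more compounds than are shown below. What is called first, only, known or untested is meant among the compounds shown, and "the series" means these compounds.

Measured so far in a functional assay (Mus musculus, strain BALB/C) for inhibition, read by MTT assay, with stated times of 24 h and 72 h; a higher number here means a weaker inhibitor, a lower number a stronger inhibitor:
compound 1, `Cc1ccc(C(=O)N/N=C/c2cc(Cl)cc(Cl)c2O)c(O)c1`: compound 1 gives 1510 nM;
compound 2, `COc1cccc(/C=N/NC(=O)c2ccc(C)cc2O)c1`: compound 2 gives 20600 nM;
compound 3, `Cc1ccc(C(=O)N/N=C/c2ccc([N+](=O)[O-])cc2)c(O)c1`: compound 3 gives 24300 nM.

Compound 2 holds the second highest of these three numbers. Its nearest neighbour is compound 3, whose number lies within the usual scatter of it, so the two cannot be told apart. Compound 1 stands far lower, well beyond the scatter.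

Compound 4, `Cc1ccc(C(=O)N/N=C/c2cccc(Br)c2)c(O)c1`, awaits measurement. It differs from compound 2 in one place: bromo in place of methoxy on an aromatic carbon. Within the data shown here, no step between measured compounds matches this change. Compound 1 is the only one of the three whose number, 1510 nM, lies far from the other two, which leaves the direction for compound 4 uncertain. Compound 4 is expected to give 12000 nM, between 3000 nM and 40000 nM. The estimated step of a 1.7-fold lower number from compound 2 to compound 4 (0.23 log units; within the scatter) in this assay is expected to be downward but modest, not far beyond the scatter.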

Compound 4, half-maximal inhibitory concentration: 28300 nM
For compound 4 the middle estimate is 2.4-fold (0.37 log units) below the measured one, and the stated range covers the measured number.
By their numbers in this assay, from the lowest: compound 1; then compounds 2, 3 and 4 (each within the scatter of the next).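

In this assay the step from methoxy to bromo on this aromatic carbon, meta to a large group, is a 1.4-fold higher number from compound 2 to compound 4 (0.14 log units; within the scatter). Among these compounds, this is the first comparison here that changes only one place, and it shows that exchanging these two groups at this position does not separate the compounds. No measurement here offers an explanation for this result.

From the compounds shown here alone, whether an amine or a carboxylic acid on the same carbon would shift the number remains open. So does whether any single change to the shared core could reach the far lower number of compound 1.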